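Methoxy in Place of Pyrazolyl on a Shared Core

The source may hold more compounds than are shown below. What is called first, only, known or untested is meant among the compounds shown, and "the series" means these compounds.

Compound 1 `COc1c(C)ccc2c1CCC2c1ncc[nH]1`: in a functional assay on CHO cells for agonist activity at Alpha-1B adrenergic receptor (Homo sapiens), read by FLIPR and calcium flux (a higher number here means that more compound is needed for the effect, a lower number that less compound is needed), compound 1 gives > 10000 nM, a limit of the assay.
Compound 2 `COc1cccc2c1CCC2c1ncc[nH]1`: in this assay compound 2 gives > 10000 nM, also a limit.
Compound 3 `Clc1ccc2c(c1-c1ccn[nH]1)CCC2c1ncc[nH]1`: in this assay compound 3 gives > 10000 nM, again a limit.

Compound 3 therefore stands at the assay limit, where every measured value sits (the limit of > 10000 nM in this assay, at which 3 of the 3 values shown sit). The change to compound 4 `COc1c(Cl)ccc2c1CCC2c1ncc[nH]1` is methoxy in place of 1H-pyrazol-5-yl on an aromatic carbon. Among the measured compounds shown here, the only measured step, a step that the two limits leave unreadable from compound 1 to compound 2, is a different change and cannot be read between two limits, so no measured step bears directly on this one. With every known value at the limit, compound 4 is expected to remain there as well, the expected step that the limit leaves unreadable from compound 3 to compound 4 being unreadable. Compound 4 is estimated at 15000 nM, in the range 5000 nM to 50000 nM.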

Compound 4, half-maximal effective concentration: > 10000 nM
Compound 4 was reported as a limit; the forecaster's own chance of this, stated with the estimate: 85%; the middle value lies beyond the limit too.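

In this assay compound 4 also stands at a limit, so the steps to it from compound 1, compound 2 and compound 3 cannot be read: the limit of > 10000 nM in this assay, at which 4 of the 4 values shown sit.

The compounds shown leave open whether any group on the shared core gives a measurable effect, and how large any of these changes would be.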